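The compounds below may be only part of what the source reports. "The series", "measured", "known", "first", "only" and "open" are said of these compounds alone.

Among the measured compounds shown here, compound 1 `CNC(=O)C[C@@H]1C[C@@H](c2ccc(Cl)c(Cl)c2)[C@H](NC(=O)c2cc(-c3c(Cl)cnn3C)c(Cl)o2)CN1` is one of three compounds measured in an assay for inhibition of RAC-alpha serine/threonine-protein kinase (Homo sapiens), read by HTRF, with a stated time of 1 h (on this read-out lower numbers stand for stronger inhibition and higher numbers for weaker inhibition), where compound 1 gives 2.64 nM. Its companions differ in the side chain on the shared core: compound 2 `Cn1ncc(Cl)c1-c1cc(C(=O)N[C@@H]2CN[C@H](CCNS(C)(=O)=O)C[C@H]2c2ccc(F)c(F)c2)oc1Cl` gives 3.29 nM in this assay, and compound 3 `CC(=O)NCC[C@@H]1C[C@@H](c2ccc(F)c(F)c2)[C@H](NC(=O)c2cc(-c3c(Cl)cnn3C)c(Cl)o2)CN1` gives 2.49 nM. All three numbers lie within the usual scatter of one another, so compound 1 cannot be set apart from compound 2 or compound 3 on this read-out.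

For the measured compounds named here, the one measured step that bears on the side chain is a 1.3-fold lower number from compound 2 to compound 3 (0.12 log units; within the scatter), an exchange of the group on the chain-terminal nitrogen that left the number essentially where it was. Compound 4 `Cn1ncc(Cl)c1-c1cc(C(=O)N[C@@H]2CN[C@H](CC(N)=O)C[C@H]2c2ccc(Cl)c(Cl)c2)oc1Cl` is made from compound 1 by a smaller exchange still: hydrogen in place of methyl on an amide-type nitrogen, reading at the next bond as methylcarbamoyl to carbamoyl. Going by the values given here, the single comparable step being within the scatter, and the change being one heavy atom at the chain end, no shift beyond the scatter is expected in this assay; the expected step is a 1.1-fold higher number from compound 1 to compound 4 (0.06 log units; within the scatter). Compound 4 is therefore estimated at 3 nM, with a range from 1.3 nM to 7 nM.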

Compound 4, half-maximal inhibitory concentration: 3.24 nM
Beside the measured number, compound 4's estimate is 1.1-fold (0.03 log units) below it; the range from low to high includes it.
By their numbers in this assay, from the lowest: compounds 3, 1, 4 and 2 (each within the scatter of the next).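

The methyl on the amide-type nitrogen of compound 1 can be exchanged for hydrogen with a result in this assay that stays within the scatter (a 1.2-fold higher number from compound 1 to compound 4 (0.09 log units; within the scatter)). Among the compounds shown here, the earlier step (a 1.3-fold lower number from compound 2 to compound 3 (0.12 log units; within the scatter)) concerned a different exchange, acetyl in place of methylsulfonyl on an amine nitrogen, so this is the first reading at the chain-end amide itself, and it shows that carbamoylmethyl and (methylcarbamoyl)methyl cannot be told apart on this read-out. Nothing given here bears on why this step is so small.

Every step shown lies within the scatter, so the compounds do not reveal what change at this chain end would move the number beyond it. Open questions include whether a carboxylic acid or an amine in place of the carbamoyl, or a cyclopropyl group on the amide-type nitrogen, would do so.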